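Aryl ether extension at the methoxy position of compound 3

The source may report more compounds than this note shows. Statements on the series, on what has been measured and on what is new or still open speak of the compounds shown alone.

Compound 3 `Nc1ccc2c(c1)CC(NCC1CCN(CCNS(=O)(=O)c3cccc4ccccc34)CC1)CCC2` gives 52 nM in an assay on isolated protein for inhibition of Neuropeptide Y receptor type 5 (Homo sapiens); on this read-out higher numbers stand for weaker inhibition and lower numbers for stronger inhibition. Compound 1 `COc1ccc2c(c1)CC(NCC1CCN(CCNS(=O)(=O)c3cccc4ccccc34)CC1)CCC2` gives 45 nM and compound 2 `Cc1ccc2c(c1)CC(NCC1CCN(CCNS(=O)(=O)c3cccc4ccccc34)CC1)CCC2` gives 72 nM, so the number for compound 3 sits between those of the other two, with both gaps within the scatter: a 1.2-fold higher number from compound 1 to compound 3 (0.06 log units; within the scatter) and a 1.4-fold lower number from compound 2 to compound 3 (0.14 log units; within the scatter), and also a 1.6-fold higher number from compound 1 to compound 2 (0.20 log units; within the scatter).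

Compound 4 `CCOC(=O)COc1ccc2c(c1)CC(NCC1CCN(CCNS(=O)(=O)c3cccc4ccccc34)CC1)CCC2` differs from compound 3 by (ethoxycarbonyl)methoxy in place of amino on an aromatic carbon. Among the measured compounds shown here, none of the three measured steps involves this entering group; the steps that bear on it are the exchanges among methoxy, methyl and amino at the same aromatic carbon, all of which stayed within the scatter. The nearest measured analogue in kind is compound 1, whose methoxy shares the ether oxygen on the ring with the entering group. On that basis no step beyond the scatter is expected in this assay for compound 4, and the expected step is a 1.3-fold higher number from compound 3 to compound 4 (0.10 log units; within the scatter). Compound 4 is estimated at 65 nM, with a range from 20 nM to 220 nM, the range widened because the entering group is larger than any of the three substituents measured so far.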

Compound 4, half-maximal inhibitory concentration: 680 nM
Estimate against measurement, compound 4: 10-fold (1.02 log units) below; the whole stated range lies below it.
By their numbers in this assay, from the lowest: compounds 1, 3 and 2 (each within the scatter of the next); then compound 4.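

Up to this point, the exchanges among methoxy, methyl and amino at this aromatic carbon had shown no step beyond the scatter, so the position could have seemed indifferent to what it carries; in this assay, (ethoxycarbonyl)methoxy ends that picture, with all three of its steps beyond the scatter (a 13-fold higher number from compound 3 to compound 4 (1.12 log units; beyond the scatter); a 9.4-fold higher number from compound 2 to compound 4 (0.98 log units; beyond the scatter); a 15-fold higher number from compound 1 to compound 4 (1.18 log units; beyond the scatter)). The comparison with compound 1 is the sharpest, since the oxygen on the aromatic ring stays and only ethoxycarbonyl enters on the saturated chain carbon (a 15-fold higher number from compound 1 to compound 4 (1.18 log units; beyond the scatter)), so an ether oxygen at this position does not by itself keep the number near those of the small substituents. No measurement at hand accounts for the higher number of compound 4.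

The compounds shown leave open whether the higher number goes with the ester or with the length of the substituent alone, which a plain propoxy chain, the free carboxylic acid or a primary amide at the same carbon would help to separate. They also leave open whether any group at this position can give a number lower than those of the small substituents beyond the scatter.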